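Nitroimidazole-oxadiazole conjugates: swapping the aryl group for pyridine

This account rests on a few compounds, and the source may have more. Where it says the series, first, only, none or still open, it means among the compounds named here.

Measured compounds in a functional assay on MCF7 cells (Homo sapiens) for cytotoxicity, read by MTT assay, with a stated time of 48 h; a lower number here means a stronger inhibitor, a higher number a weaker inhibitor:
- compound 1 `Cc1ncc([N+](=O)[O-])n1CCSc1nnc(-c2ccc(N)cc2)o1`: 19800 nM
- compound 2 `COc1ccc(-c2nnc(SCCn3c([N+](=O)[O-])cnc3C)o2)c(O)c1`: 21800 nM
- compound 3 `COc1cc(-c2nnc(SCCn3c([N+](=O)[O-])cnc3C)o2)cc(OC)c1OC`: 30600 nM

The three compounds share a core that joins a nitroimidazole through a short thioether linker to a five-membered aromatic ring with two nitrogen and one oxygen, and they differ only in the aromatic group carried on that ring. Compound 1 has the lowest of the three numbers in this assay, but compound 2 and compound 3 both lie within the usual scatter of it, so the three cannot be told apart on these data. Within the data shown here, none of the compounds differ from one another in a single place, so no single-point step has been measured.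

Compound 4 `Cc1ncc([N+](=O)[O-])n1CCSc1nnc(-c2cccnc2)o1` has not yet been tested. It is compound 1 with pyridin-3-yl in place of 4-aminophenyl on an aromatic carbon. The change removes the hydrogen-bond donor counted for the leaving group while keeping one acceptor. Among the measured compounds shown here, with no measured step to lean on, and with the three measured compounds sitting together, the step from compound 1 to compound 4 is expected to be small: a 1.3-fold higher number from compound 1 to compound 4 (0.10 log units; within the scatter), not clearly beyond the scatter in either direction. Compound 4 is therefore expected to give about 25000 nM in this assay, within roughly 10000 nM to 60000 nM.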

Compound 4, half-maximal inhibitory concentration: 28700 nM
Compound 4: middle estimate off by 1.1-fold (0.06 log units), on the low side, and the stated range covers the measured number.
By their numbers in this assay, from the lowest: compounds 1, 2, 4 and 3 (each within the scatter of the next).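

In this assay, among these compounds, the exchange of 4-aminophenyl for pyridin-3-yl on an aromatic carbon gives the first single-place step at this position (a 1.4-fold higher number from compound 1 to compound 4 (0.16 log units; within the scatter)), and that step lies within the usual scatter. At this position, then, a six-membered aromatic ring of carbon only that carries an amine and a six-membered aromatic ring with 1 hetero atom cannot be told apart, even though the count of hydrogen-bond donors goes from 1 to 0 while the 1 hydrogen-bond acceptor stays. No measurement shown here accounts for this result, so the data give no reason why the two compounds sit together.

The compounds shown leave open whether any group at this position would carry the number beyond the scatter, for example a carboxylic acid or a morpholine ring on the aryl group, in place of the amine of compound 1. They also leave open whether a longer chain in place of the short thioether linker of the shared core would change the number in either direction.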